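A Second Chlorine Added to a Chlorophenyl Imine

The source may hold more compounds than are shown below. What is called first, only, known or untested is meant among the compounds shown, and "the series" means these compounds.

Of the compounds shown here, three built on one shared core have been tested for their effect on colon cancer cells. Compound 1 `CCOc1cccc(/C=N/c2c(C)n(C)n(-c3ccccc3)c2=O)c1` gives 295000000 nM in a functional assay on HT-29 cells (Homo sapiens) for cytotoxicity, read by MTT assay, with a stated time of 72 h; a lower number here means a stronger inhibitor, a higher number a weaker inhibitor. Compound 3 `Cc1c(/N=C/c2cccc([N+](=O)[O-])c2)c(=O)n(-c2ccccc2)n1C` gives 741000000 nM in this assay, and compound 2 `Cc1c(/N=C/c2ccccc2Cl)c(=O)n(-c2ccccc2)n1C` gives 309000000 nM. Among these three numbers compound 2 holds the second highest; its number and that of compound 1 lie within the usual scatter of one another, while the number of compound 3 lies beyond it. Among the compounds with values here, the only step between two measured compounds that differ in a single place is a 2.5-fold higher number from compound 1 to compound 3 (0.40 log units; beyond the scatter), a modest change.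

Compound 4 `Cc1c(/N=C/c2ccc(Cl)cc2Cl)c(=O)n(-c2ccccc2)n1C` has not yet been measured. It differs from compound 2 by chloro in place of hydrogen on an aromatic carbon. Within the data shown here, none of the measured steps concerns the entry of a chloro group, so nothing among the measured compounds speaks directly to this change; the lone step between compound 1 and compound 3 involves an unrelated exchange. In this assay the step expected here is a 1.0-fold lower number from compound 2 to compound 4 (0.01 log units; within the scatter), that is, no change beyond the scatter. Compound 4 is estimated at 300000000 nM, with a range from 130000000 nM to 700000000 nM.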

Compound 4, half-maximal inhibitory concentration: 178000000 nM
Estimate against measurement, compound 4: 1.7-fold (0.23 log units) above, within the range that was stated.
By their numbers in this assay, from the lowest: compounds 4, 1 and 2 (each within the scatter of the next); then compound 3.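

Among the compounds measured so far, only this pair shows what the entry of a chloro group does. In this assay the change from 2-chlorophenyl to 2,4-dichlorophenyl gives a 1.7-fold lower number from compound 2 to compound 4 (0.24 log units; within the scatter) and so stays within the usual scatter of repeated measurements. At this place on the ring, para to a large group and meta to a chloro group, a second chlorine therefore brings no change that can be told apart from that scatter, although this single pair says nothing about any other place on the ring, and no measurement shown here offers an explanation for the result.

On these data alone, it remains open whether a different group at this same place, such as a methoxy group, an amine or a carboxylic acid, would move the number beyond the scatter. As far as these compounds go, it is also open whether a chloro group at this place would give the same small step on a ring that does not already carry the first chloro group.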